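A few compounds are considered here, and "the series" means these few. Any claim that something is new, unique, unknown or untested is made for them only; others in the source may bear on it.

Measured so far:
compound 1, `CC(=O)NCc1cccc(Cn2nc(NS(=O)(=O)c3ccc(Cl)s3)c3c(Cl)cccc32)c1`, 3.8;
compound 2, `CC(=O)NCc1cccc(Cn2nc(NS(=O)(=O)c3ccc(Cl)s3)c3c(F)cccc32)c1`, 3;
compound 3, `CC(=O)NCc1cccc(Cn2nc(NS(=O)(=O)c3ccc(Cl)s3)c3c(CO)cccc32)c1`, 2.6.

In a physicochemical assay for lipophilicity (a higher number here means a more lipophilic compound, a lower number a more polar compound), compound 3 gives the lowest of the three numbers, and the gaps to the others lie beyond the scatter: a number 1.20 log units lower from compound 1 to compound 3 (beyond the scatter) and a number 0.40 log units lower from compound 2 to compound 3 (beyond the scatter). The step to compound 4, `CC(=O)NCc1cccc(Cn2nc(NS(=O)(=O)c3ccc(Cl)s3)c3c(C(C)=O)cccc32)c1`, is acetyl in place of hydroxymethyl on an aromatic carbon. For the measured compounds named here, no measured step carries an acetyl group, so the only guide is that hydroxymethyl went with the lowest number in the set, as the steps from compound 1 and compound 2 to compound 3 show. Replacing it with acetyl is therefore expected to raise the number by a modest step, a number 0.50 log units higher from compound 3 to compound 4 (beyond the scatter). Compound 4 is estimated at 3.1, within the range 2.7 to 3.5.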

Compound 4, distribution coefficient: 4.8
Estimate against measurement, compound 4: 1.70 log units below; measured number outside the range, above it.
By their numbers in this assay, from the lowest: compound 3; then compound 2; then compound 1; then compound 4.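

For the compounds shown here, at this position on the shared core, the earlier compounds showed only steps down from chloro, whereas acetyl gives the highest number of the four in this assay, with a number 1.00 log units higher from compound 1 to compound 4 (beyond the scatter) and a number 1.80 log units higher from compound 2 to compound 4 (beyond the scatter) and a number 2.20 log units higher from compound 3 to compound 4 (beyond the scatter) in the largest step. Acetyl and hydroxymethyl differ here by a single heavy atom and the loss of the hydrogen-bond donor, so a small change in structure can move this number a long way. No measurement at hand explains why. Where an amine, a carboxylic acid or a longer chain ending in a carbonyl would fall in this assay remains open.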